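This account rests on a few compounds, and the source may have more. Where it says the series, first, only, none or still open, it means among the compounds named here.

Going by the values given here, compound 2 `C#CCN(CCCOc1ccc2ccc(=O)oc2c1)Cc1ccc(C)cc1` and compound 1 `C#CCN(CCCCOc1ccc2ccc(=O)oc2c1)Cc1ccc(OC)cc1` are the two measured members. In an assay on isolated protein for inhibition of Amine oxidase [flavin-containing] B (Homo sapiens), read by fluorescence and Amplex Red, with stated times of 15 min and 20 min (on this read-out higher numbers stand for weaker inhibition and lower numbers for stronger inhibition), compound 2 gives 7380 nM, the highest of the two numbers; compound 1 gives 1130 nM, and the gap between them is beyond the scatter, though the two differ in both chain length and aryl group. Compound 3 `C#CCN(CCCOc1ccc2ccc(=O)oc2c1)Cc1cccc(OC)c1` follows from compound 2 by 3-methoxyphenyl in place of 4-methylphenyl on a saturated chain carbon bound to an amine nitrogen. Among the compounds with values here, with no single-change step available, the expected step from compound 2 to compound 3 is a 2.5-fold lower number from compound 2 to compound 3 (0.39 log units; beyond the scatter), a modest move toward stronger inhibition. Compound 3 is estimated at 3000 nM, within 1000 nM to 9000 nM.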

Compound 3, half-maximal inhibitory concentration: 4590 nM
For compound 3 the middle estimate is 1.5-fold (0.18 log units) below the measured one, within the range that was stated.
By their numbers in this assay, from the lowest: compound 1; then compounds 3 and 2 (each within the scatter of the next).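

In this assay, going by these compounds alone, 3-methoxyphenyl in place of 4-methylphenyl on a saturated chain carbon bound to an amine nitrogen gives a 1.6-fold lower number from compound 2 to compound 3 (0.21 log units; within the scatter), the first single-place reading. On this read-out, the two aryl groups are not told apart at this position, although 3-methoxyphenyl carries one hydrogen-bond acceptor and 4-methylphenyl none. Nothing available bears on why they read alike. From the compounds shown here alone, what the longer chain of compound 1 contributes on its own stays open, as does how a 3-chlorophenyl group would read at this place.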